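Trimming a side chain on a serine protease inhibitor

The compounds below may be only part of what the source reports. "The series", "measured", "known", "first", "only" and "open" are said of these compounds alone.

Compound 2 `COC(=O)[C@H](Cc1cccc(C(=N)N)c1)[C@@H](CC1CCCCC1)NC(=O)c1ccc(-c2cccc(CN)c2)cc1` was tested in an assay on isolated protein for inhibition of serine protease 1 (Homo sapiens) (a lower number here means a stronger inhibitor, a higher number a weaker inhibitor), and gives 36 nM. Compound 1 `COC(=O)[C@H](Cc1cccc(C(=N)N)c1)[C@@H](C)NC(=O)c1ccc(-c2ccc(C(N)=O)cc2)cc1` gives 42 nM in this assay, and the two numbers lie within the usual scatter of each other, so neither stands apart. Compound 3 `COC(=O)[C@H](Cc1cccc(C(=N)N)c1)[C@H](NC(=O)c1ccc(-c2cccc(CN)c2)cc1)C(C)C` has not yet been measured; it differs from compound 2 by isopropyl in place of cyclohexylmethyl on a saturated chain carbon bound to an amide-type nitrogen and a saturated chain carbon. Within the data shown here, no measured pair shows what such a change does here, so the expected step from compound 2 to compound 3 is small, a 1.7-fold higher number from compound 2 to compound 3 (0.22 log units; within the scatter), with a slight lean towards a higher number. Compound 3 is therefore expected to give about 60 nM, likely between 20 nM and 200 nM.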

Compound 3, inhibition constant: 300 nM
Estimate against measurement, compound 3: 5.0-fold (0.70 log units) below; the whole stated range lies below it.
By their numbers in this assay, from the lowest: compounds 2 and 1 (each within the scatter of the next); then compound 3.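

Replacing cyclohexylmethyl with isopropyl on this saturated chain carbon gives an 8.3-fold higher number from compound 2 to compound 3 (0.92 log units; beyond the scatter) in this assay and lies beyond the usual scatter. This position therefore responds to the change, and in this pair the larger, ring-bearing group of 7 heavy atoms goes with the stronger inhibitor. Nothing measured here explains the step.

On these data alone, whether the ring itself or only the size of the group matters remains open. A straight butyl chain or a benzyl group on the same carbon could help separate the two.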